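The source may hold more compounds than are shown below. What is called first, only, known or untested is meant among the compounds shown, and "the series" means these compounds.

Measured so far: compound 1 `CS(=O)(=O)Nc1cccc(-c2nc(C(c3ccc(F)cc3)c3ccc(F)cc3)sc2CC(=O)O)c1` and compound 2 `O=C(O)Cc1sc(C(c2ccc(F)cc2)c2ccc(F)cc2)nc1-c1cn[nH]c1`.

In an in vitro assay on HEK385-7 cells for displacement of a labelled ligand from prostaglandin D2 receptor 2 (Homo sapiens) (on this read-out higher numbers stand for weaker inhibition and lower numbers for stronger inhibition), compound 1 gives 40 nM. In this assay, among the measured compounds shown here, compound 2 gives 16 nM, the lowest of the two numbers; the single step, a 2.5-fold lower number from compound 1 to compound 2 (0.40 log units; beyond the scatter), lies beyond the scatter.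

Compound 3 `O=C(O)Cc1sc(C(c2ccc(F)cc2)c2ccc(F)cc2)nc1-c1ccncc1` carries pyridin-4-yl in place of 1H-pyrazol-4-yl on an aromatic carbon. Only a 2.5-fold lower number from compound 1 to compound 2 (0.40 log units; beyond the scatter) bears on this change, and loosely, as both steps alter the same aromatic group but the leaving groups differ. With one hydrogen-bond donor fewer, a modest rise is expected, a 2.2-fold higher number from compound 2 to compound 3 (0.34 log units; beyond the scatter). Compound 3 is estimated at 35 nM, range 12 nM to 110 nM.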

Compound 3, half-maximal inhibitory concentration: 5.3 nM
Compound 3: middle estimate off by 6.6-fold (0.82 log units), on the high side; the whole stated range lies above it.
By their numbers in this assay, from the lowest: compound 3; then compound 2; then compound 1.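

In this assay, the aromatic carbon next to the ring nitrogen accepts a group with no hydrogen-bond donor: a 3.0-fold lower number from compound 2 to compound 3 (0.48 log units; beyond the scatter). Pyridin-4-yl also replaces 3-(methanesulfonamido)phenyl with a 7.5-fold lower number from compound 1 to compound 3 (0.88 log units; beyond the scatter), so among these three compounds a lower number does not depend on the donor that both other groups carry. No measurement here accounts for either step.

The swap to pyridin-4-yl changes ring size and donor count together, and the two remain unseparated. Also open, going by these compounds, is whether a pyridin-3-yl or an unsubstituted phenyl on this carbon would keep the number as low.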